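This account rests on a few compounds, and the source may have more. Where it says the series, first, only, none or still open, it means among the compounds named here.

The measured compounds and their values:

Compound 1 `CCc1cccc(NC(=O)CN2CCC(c3cccc[n+]3[O-])CC2)c1` reaches 62% in a functional assay on HEK293 cells for agonist activity at D(4) dopamine receptor (Homo sapiens), read by FLIPR; on this read-out higher numbers stand for larger maximal responses and lower numbers for smaller maximal responses.
Compound 2 `Cc1cccc(NC(=O)CN2CCC(c3nccs3)CC2)c1` reaches 62% in this assay.
Compound 3 `COc1ccccc1C1CCN(CC(=O)Nc2cccc(C)c2)CC1` reaches 43% in this assay.

Compound 3 stands lowest of the three numbers; compounds 1 and 2 each sit higher, and both gaps are beyond the scatter. Among the measured compounds shown here, the one recorded step, a number 19 percentage points lower from compound 2 to compound 3 (beyond the scatter), belongs to the change 2-methoxyphenyl in place of 1,3-thiazol-2-yl on a saturated ring carbon. Compound 4 `Cc1cccc(NC(=O)CN2CCC(c3cccc(F)c3)CC2)c1` differs from compound 3 in one place: 3-fluorophenyl in place of 2-methoxyphenyl on a saturated ring carbon. For the measured compounds named here, no measured step exchanges one carbon-only aromatic ring for another at this position, so the recorded step bears on the new change only indirectly: it shows that the group on this saturated ring carbon can move this assay by a modest amount, and that 2-methoxyphenyl gave the lowest number of the set. Compound 4 is therefore expected to sit somewhat higher than compound 3, and the estimated step is a number 9 percentage points higher from compound 3 to compound 4 (within the scatter). For compound 4 the expected value in this assay is 52%, with a range from 35% to 70%.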

Compound 4, largest response reached (reported as efficacy), in percent of the reference or control that the assay uses: 40%
Beside the measured number, compound 4's estimate is 12 percentage points above it; measured number inside the range.
By their numbers in this assay, from the lowest: compounds 4 and 3 (each within the scatter of the next); then compounds 1 and 2 (each within the scatter of the next).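

In this assay the step of a number 3 percentage points lower from compound 3 to compound 4 (within the scatter) lies within the scatter, so on this saturated ring carbon 2-methoxyphenyl and 3-fluorophenyl cannot be told apart, although they carry different substituents at different ring positions. The step of a number 22 percentage points lower from compound 2 to compound 4 (beyond the scatter) lies beyond the scatter, so the gap to the 1,3-thiazol-2-yl group seen with compound 3 is now seen with a second substituted phenyl group. Nothing at hand explains why the two phenyl groups read alike or why both stand apart from the 1,3-thiazol-2-yl group.

Two substituted phenyl groups cannot show how far this likeness extends, and a phenyl ring carrying an amine or a carboxylic acid could read differently. Going by these compounds, it also remains open whether an unsubstituted phenyl or a 1,3-oxazol-2-yl group would fall with compound 3 and compound 4 or with compound 2.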